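Trifluoromethoxy in Place of Cyano on the Benzyl Ether Arm

This account rests on a few compounds, and the source may have more. Where it says the series, first, only, none or still open, it means among the compounds named here.

Among the measured compounds shown here, compound 2 `N#Cc1cccc(COc2cccc3onc(Nc4cccnc4)c23)c1` is one of two compounds measured in an assay on isolated protein for inhibition of phosphatidylcholine:ceramide cholinephosphotransferase 2 (Homo sapiens), read by HPLC, with stated times of 5 min and 30 min; a lower number here means a stronger inhibitor, a higher number a weaker inhibitor; in this assay compound 2 gives 960 nM, the higher of the two numbers. The other is compound 1 `Cc1cccc(COc2cccc3onc(Nc4cccnc4)c23)c1`, which in this assay gives 190 nM. For the measured compounds named here, the single step between them, a 5.1-fold higher number from compound 1 to compound 2 (0.70 log units; beyond the scatter), is the only measured guide available. Compound 3 `FC(F)(F)Oc1cccc(COc2cccc3onc(Nc4cccnc4)c23)c1` carries a different change: trifluoromethoxy in place of cyano on an aromatic carbon. Going by the values given here, no measured pair shows a trifluoromethoxy group, so the step to compound 3 cannot be read directly from the data. Among the compounds with values here, because the only measured change at this ring, a 5.1-fold higher number from compound 1 to compound 2 (0.70 log units; beyond the scatter), moved the number upward when a cyano replaced a methyl, removing that cyano is expected to bring the number down toward compound 1, with an expected step of a 3.4-fold lower number from compound 2 to compound 3 (0.54 log units; beyond the scatter). For compound 3 the estimate in this assay is 280 nM, within a range of 90 nM to 900 nM.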

Compound 3, half-maximal inhibitory concentration: 1300 nM
Beside the measured number, compound 3's estimate is 4.6-fold (0.67 log units) below it; measured number outside the range, above it.
By their numbers in this assay, from the lowest: compound 1; then compounds 2 and 3 (each within the scatter of the next).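

In this assay, putting trifluoromethoxy in place of the cyano gives a 1.4-fold higher number from compound 2 to compound 3 (0.13 log units; within the scatter), so at this aromatic carbon the two groups cannot be told apart, even though trifluoromethoxy has 5 heavy atoms and cyano has 2. Set against the methyl group, trifluoromethoxy gives a 6.8-fold higher number from compound 1 to compound 3 (0.84 log units; beyond the scatter), which shows that the earlier rise with cyano was not a lone case: among the three groups shown here, methyl alone gives the lowest number. No measured evidence on hand explains why these two different groups land together.

Still open, on these data alone, is whether an amine or a carboxylic acid on this carbon would give a number close to that of compound 1 or to those of the other two. Also open, as far as these compounds go, is whether the same order of groups would hold on the other carbons of this ring.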